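This account rests on a few compounds, and the source may have more. Where it says the series, first, only, none or still open, it means among the compounds named here.

Measured so far in a functional assay on NCI-H522 cells (Homo sapiens) for inhibition, read by sulforhodamine B assay, with a stated time of 48 h; a higher number here means a weaker inhibitor of growth, a lower number a stronger inhibitor of growth:

compound 1 `Nc1cc(N)c2nc(-c3ccccc3)c(Oc3ccc(F)cc3)nc2c1`: < 100000 nM
compound 2 `COc1cc(CNc2nc3cc(N)cc(N)c3nc2-c2ccccc2)cc(OC)c1OC`: < 50200 nM
compound 3 `CCOC(=O)[C@H](CCC(=O)O)NC(=O)c1ccc(Oc2nc3cc(N)cc(N)c3nc2-c2ccccc2)cc1`: < 100000 nM

None of these three values is a number; each is a limit of the assay. For compound 1 the value < 100000 nM is such a limit, the one described by the limit of < 100000 nM in this assay, at which 2 of the 3 values shown sit. Compound 3 reports only a limit as well. For compound 2 the reported value < 50200 nM is also a limit, as set out in the limit of < 50200 nM in this assay, at which 1 of the 3 values shown sits. Compound 1 therefore stands nowhere in particular on the numbers shown: with only limits on all three compounds, no ordering among them can be read, and no step between measured compounds can be stated.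

Compound 4 `Nc1cc(N)c2nc(-c3ccccc3)c(NCc3ccc(F)cc3)nc2c1` is the next compound for this assay. Relative to compound 1 the change is (4-fluorobenzyl)amino in place of 4-fluorophenoxy on an aromatic carbon.

Since the measured values are limits only, there is no basis to expect a step in either direction, and the step from compound 1 to compound 4 a step that the limit leaves unreadable from compound 1 to compound 4 is expected to be none beyond the scatter. For compound 4 the estimate in this assay is 60000 nM, with a range from 15000 nM to 100000 nM, and most likely the assay will again report only a limit.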

Compound 4, concentration for total growth inhibition: < 100000 nM
Compound 4 ended at the assay's limit (the forecaster's own chance of this, stated with the estimate: 70%); the middle value lies beyond the limit too.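

In this assay compound 1 and compound 4 both report only a limit of the assay, so no step between them can be read: the limit of < 100000 nM in this assay, at which 3 of the 4 values shown sit.

The compounds shown leave open how (4-fluorobenzyl)amino and 4-fluorophenoxy on the shared core compare, and how any of the four compounds ranks against the others.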